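Replacing 2-Carboxyethenyl with 2-Hydroxyethyl

The source may hold more compounds than are shown below. What is called first, only, known or untested is meant among the compounds shown, and "the series" means these compounds.

In a functional assay on Daudi cells (Homo sapiens) for inhibition, read by resazurin assay, with a stated time of 24 h (a lower number here means a stronger inhibitor of growth, a higher number a weaker inhibitor of growth), compound 1 `NC(=O)c1ccccc1Nc1cccc(Oc2ccccc2)c1` gives 31000 nM. Compound 2 `NC(=O)c1ccccc1Nc1cccc(/C=C/C(=O)O)c1` gives > 100000 nM, which is a limit of the assay and not a number. Among the compounds with values here, the one measured step, an at least 3.2-fold higher number from compound 1 to compound 2 (0.50 log units; beyond the scatter), is beyond the scatter and bears on the same place on the shared core. Compound 3 `NC(=O)c1ccccc1Nc1cccc(CCO)c1` changes compound 2 at that place: 2-hydroxyethyl in place of 2-carboxyethenyl on an aromatic carbon. Within the data shown here, with only this step as a guide, a small move towards a lower number is expected, and the result may again be a limit. The estimated step is an at least 1.4-fold lower number from compound 2 to compound 3 (0.15 log units; that floor lies within the scatter). Compound 3 is expected at 70000 nM, within an estimated range of 25000 nM to 180000 nM.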

Compound 3, concentration for 50% growth inhibition: > 100000 nM
Compound 3 gave a limit, no number; the forecaster's own chance of this, stated with the estimate: 40%; middle value at least 1.4-fold (0.15 log units) away from the limit.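

In this assay compound 3 gives > 100000 nM, a limit of the assay and not a number. Replacing phenoxy with 2-hydroxyethyl gives an at least 3.2-fold higher number from compound 1 to compound 3 (0.50 log units; beyond the scatter), so a second replacement without a ring also weakens growth inhibition at this position. The step between compound 2 and compound 3 cannot be read, because both stop at the same ceiling: the limit of > 100000 nM in this assay, at which 2 of the 3 values shown sit.

As far as these compounds go, whether an amine or a longer chain at this position would give a measurable number remains open. From the compounds shown here alone, how far the true values of compound 2 and compound 3 lie beyond the limit also remains unknown.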